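From Cyclohexyl to Phenyl on a Piperazine Nitrogen

This account rests on a few compounds, and the source may have more. Where it says the series, first, only, none or still open, it means among the compounds named here.

Three compounds have been measured in an assay on CHO cells for antagonist activity at transient receptor potential cation channel subfamily V member 1 (Homo sapiens), read by FLIPR; a higher number here means a weaker inhibitor, a lower number a stronger inhibitor:

Compound 1, `CC1CCN(c2cc(C(F)(F)F)ccc2CNC(=O)C(C)c2ccc(NS(C)(=O)=O)c(F)c2)CC1`: 0.9 nM
Compound 2, `CCC1CCN(c2cc(C(F)(F)F)ccc2CNC(=O)C(C)c2ccc(NS(C)(=O)=O)c(F)c2)CC1`: 0.7 nM
Compound 3, `CC(C(=O)NCc1ccc(C(F)(F)F)cc1N1CCN(C2CCCCC2)CC1)c1ccc(NS(C)(=O)=O)c(F)c1`: 13.8 nM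

Compound 3 stands at the highest of the three numbers. The steps leading to it are large: a 15-fold higher number from compound 1 to compound 3 (1.19 log units; beyond the scatter) and a 20-fold higher number from compound 2 to compound 3 (1.29 log units; beyond the scatter), both beyond the scatter. Between the first two compounds the difference is small, a 1.3-fold lower number from compound 1 to compound 2 (0.11 log units; within the scatter).

Compound 4, `CC(C(=O)NCc1ccc(C(F)(F)F)cc1N1CCN(c2ccccc2)CC1)c1ccc(NS(C)(=O)=O)c(F)c1`, has not yet been measured. It differs from compound 3 in one place: phenyl in place of cyclohexyl on an amine nitrogen in a ring. For the measured compounds named here, none of the measured steps touches this part of the molecule. The two large steps replace the whole group on the aromatic carbon, and the small step alters a saturated chain elsewhere. There is thus no direct guide to how a phenyl in place of a cyclohexyl on the amine nitrogen in a ring will read in this assay. The expectation is therefore for no step beyond the scatter, with a wide range to reflect the lack of a comparable example.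

Compound 4 is estimated at 12 nM, between 3 nM and 50 nM. That corresponds to an expected step of a 1.2-fold lower number from compound 3 to compound 4 (0.06 log units; within the scatter).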

Compound 4, inhibition constant: 2 nM
Compound 4: middle estimate off by 6.0-fold (0.78 log units), on the high side; the measured number lies below the stated range.
By their numbers in this assay, from the lowest: compounds 2 and 1 (each within the scatter of the next); then compound 4; then compound 3.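

In this assay, the group on an amine nitrogen in a ring clearly matters: with the rest of the molecule unchanged, phenyl in place of cyclohexyl gives a 6.9-fold lower number from compound 3 to compound 4 (0.84 log units; beyond the scatter), although both groups hold 6 carbon atoms and differ in whether their six-membered ring is aromatic. This closes much of the gap opened by 4-cyclohexylpiperazin-1-yl, but not all of it: 4-phenylpiperazin-1-yl in place of 4-ethylpiperidin-1-yl still gives a 2.9-fold higher number from compound 2 to compound 4 (0.46 log units; beyond the scatter), and in place of 4-methylpiperidin-1-yl it gives a 2.2-fold higher number from compound 1 to compound 4 (0.35 log units; beyond the scatter), so compound 1 and compound 2 both remain ahead of compound 4 by more than the scatter. No measurement at hand explains why the aromatic ring reads better at this position.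

With only cyclohexyl and phenyl shown on this nitrogen, two examples cannot reveal a trend. A benzyl group, a pyridine ring, or a phenyl ring carrying a fluorine atom could show whether any group here can match compound 1 and compound 2 in this assay.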